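Phenylsulfonyl to dimethylsulfamoyl: expected maximal response

This account rests on a few compounds, and the source may have more. Where it says the series, first, only, none or still open, it means among the compounds named here.

Two compounds of the series carry measured numbers. Going by the values given here, compound 1 `Cc1ccc2[nH]c(C(=O)N[C@H]3CN(S(=O)(=O)c4ccnnc4)C[C@@H]3C(=O)NCCN(C)C)cc2c1` and compound 2 `Cc1ccc2[nH]c(C(=O)N[C@H]3CCN(S(=O)(=O)c4ccccc4)C[C@@H]3C(=O)NCCN(C)C)cc2c1` differ from each other in more than one place, so no single structural step separates them and only their two values are compared. In a functional assay on HEK293 cells for agonist activity at growth hormone secretagogue receptor type 1 (Homo sapiens), read by HTRF and inositol phosphate accumulation, with a stated time of 90 min, in the presence of a further agent that is not named here (a lower number here means a smaller maximal response, a higher number a larger maximal response), compound 2 gives 98% and compound 1 gives 89%; the gap between them lies within the usual scatter, so compound 2 and compound 1 stand together near a full response, with compound 2 holding the numerically upper of the two figures.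

The next compound, compound 3 `Cc1ccc2[nH]c(C(=O)N[C@H]3CCN(S(=O)(=O)N(C)C)C[C@@H]3C(=O)NCCN(C)C)cc2c1`, keeps the whole of compound 2 apart from the group on the sulfonyl sulfur: dimethylamino in place of phenyl on a sulfonyl sulfur. Among the compounds with values here, no measured pair shows this change, so nothing known here sets its size. With both measured compounds near a full response in this assay, the expectation is that the step from compound 2 to compound 3 stays small, with a modest drop at most, a number 8 percentage points lower from compound 2 to compound 3 (within the scatter). Compound 3 is therefore estimated to reach 90% in this assay, in a range from 70% to 105%.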

Compound 3, largest response reached (Emax), in percent of the reference or control that the assay uses: 100%
Beside the measured number, compound 3's estimate is 10 percentage points below it; low and high end bracket the measured number.
By their numbers in this assay, from the lowest: compounds 1, 2 and 3 (each within the scatter of the next, the first and the last beyond it).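

Dimethylamino in place of phenyl on a sulfonyl sulfur provides the first single-place comparison in the series: in this assay the change gives a number 2 percentage points higher from compound 2 to compound 3 (within the scatter). On this sulfonyl sulfur, whose other neighbour is the sulfonamide nitrogen in a ring, the six-membered aromatic ring of carbon only can therefore give way to an open group carrying nitrogen with no change in maximal response beyond the scatter, something the earlier pair could not show because its members differ in more than one place. No measurement at hand accounts for this result.

Still open, going by these compounds, is whether the same sulfonyl sulfur tolerates other groups in this assay, such as methyl, morpholine, a longer alkyl chain or a phenyl ring carrying a carboxylic acid, since a single step from phenyl to dimethylamino defines no trend. The read-out gives only the largest response reached, so the compounds shown leave open how the change affects the concentration needed for that response, and whether the same holds on the other ring form of the core seen in compound 1.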